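Piperidine for methylpiperazine on a shared amide core

This account rests on a few compounds, and the source may have more. Where it says the series, first, only, none or still open, it means among the compounds named here.

Compound 1 `CN1CCN(C(=O)CNC(=O)c2ccc(S(C)(=O)=O)c([N+](=O)[O-])c2)CC1` was examined in an ADME assay on HepG2 cells (Homo sapiens) for cytotoxicity, read by CellTiter-Glo and ATP content, with a stated time of 72 h; on this read-out lower numbers stand for an effect already at smaller amounts and higher numbers for an effect only at larger amounts of compound. In this assay compound 1 gives only a limit, > 27000 nM. Compound 2 `CS(=O)(=O)c1ccc(C(=O)NCC(=O)N2CCN(c3ccccc3F)CC2)cc1[N+](=O)[O-]` carries 2-fluorophenyl in place of methyl on an amine nitrogen in a ring. In this assay compound 2 also gives only a limit, > 27000 nM. The step that the two limits leave unreadable from compound 1 to compound 2 therefore cannot be read, and the whole record consists of the limit of > 27000 nM in this assay, at which 2 of the 2 values shown sit. Compound 3 `CS(=O)(=O)c1ccc(C(=O)NCC(=O)N2CCCCC2)cc1[N+](=O)[O-]` differs from compound 1 by piperidin-1-yl in place of 4-methylpiperazin-1-yl on a carbonyl carbon. Among the measured compounds shown here, no measured step touches this change, so nothing in the data points to a direction. Given that both measured compounds stop at the same limit, compound 3 is expected to give about 27000 nM, within a range from 14000 nM to 60000 nM, most likely reported again only as a limit. The expected step of a number no higher from compound 1 to compound 3 (the limit leaves the size open) is thus none beyond the scatter.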

Compound 3, half-maximal effective concentration: 14000 nM
Compound 3: the middle estimate sits 1.9-fold (0.29 log units) above what was measured; low and high end bracket the measured number.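

In this assay compound 3 is the only one of the three to give a number rather than a limit, 14000 nM, so this position on the carbonyl carbon can yield a readable value within the tested range. Piperidin-1-yl in place of 4-methylpiperazin-1-yl, a change that leaves out one ring nitrogen, gives an at least 1.9-fold lower number from compound 1 to compound 3 (0.28 log units; that floor lies within the scatter), so the data do not establish a real separation between the two compounds. The other two values are limits, not numbers: the limit of > 27000 nM in this assay, at which 2 of the 3 values shown sit.

On these data alone, how far compound 1 truly lies from compound 3 stays open, as only the floor of that step can be read. Also open, as far as these compounds go, is whether morpholin-4-yl or an open-chain amine on the same carbonyl carbon would give a number or stop at the limit.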